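A few compounds are considered here, and "the series" means these few. Any claim that something is new, unique, unknown or untested is made for them only; others in the source may bear on it.

Measured compounds:
- compound 1 `CCN(CC)c1ccc2cc(C(=O)c3ccc(N4CCN(C(=O)CN5CCNCC5)CC4)cc3)oc2c1`: 1350 nM
- compound 2 `CCN(CC)c1ccc2cc(C(=O)c3ccc(N4CCN(C(=O)CN5CCN(C(=O)CCl)CC5)CC4)cc3)oc2c1`: 5520 nM
- compound 3 `CCN(CC)c1ccc2cc(C(=O)c3ccc(N4CCN(C(=O)CN5CCN(S(=O)(=O)c6ccc(OC(F)(F)F)cc6)CC5)CC4)cc3)oc2c1`: 30200 nM

In a functional assay on HeLa cells (Homo sapiens) for cytotoxicity, read by MTT assay, with a stated time of 48 h (on this read-out higher numbers stand for weaker inhibition and lower numbers for stronger inhibition), compound 1 gives the lowest of the three numbers; compound 2 comes nearest with a 4.1-fold higher number from compound 1 to compound 2 (0.61 log units; beyond the scatter), and compound 3, with its (4-trifluoromethoxyphenyl)sulfonyl group on the same ring nitrogen, gives the highest number, 30200 nM.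

Compound 4 `CCN(CC)c1ccc2cc(C(=O)c3ccc(N4CCN(C(=O)CN5CCN(S(=O)(=O)c6ccc(F)cc6)CC5)CC4)cc3)oc2c1` is not yet measured. It differs from compound 1 in one place: (4-fluorophenyl)sulfonyl in place of hydrogen on an amine nitrogen in a ring. Both measured steps from compound 1 bear on it, since each puts a group on the same ring nitrogen: acylation with the chloroacetyl group gives a 4.1-fold higher number from compound 1 to compound 2 (0.61 log units; beyond the scatter), and the arylsulfonyl substitution of compound 3 gives a number well beyond that of compound 2. A sulfonyl group close in kind to that of compound 3 is therefore expected to raise the number clearly, with the step of an 11-fold higher number from compound 1 to compound 4 (1.05 log units; beyond the scatter) expected in this assay. For compound 4 the estimate in this assay is 15000 nM, within 4000 nM to 50000 nM.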

Compound 4, half-maximal inhibitory concentration: 16700 nM
The estimate for compound 4 lay 1.1-fold (0.05 log units) below the measured number; the range from low to high includes it.
By their numbers in this assay, from the lowest: compound 1; then compound 2; then compounds 4 and 3 (each within the scatter of the next).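

In this assay, (4-fluorophenyl)sulfonyl in place of hydrogen on the ring nitrogen gives a 12-fold higher number from compound 1 to compound 4 (1.09 log units; beyond the scatter) and is a large step, so a second arylsulfonyl compound now stands well away from the free amine. The substituent on the aromatic ring does not separate the two sulfonyl compounds, with fluoro in place of trifluoromethoxy giving a 1.8-fold lower number from compound 3 to compound 4 (0.26 log units; within the scatter), whereas the kind of group on the nitrogen does separate compound 2 and compound 4, with the sulfonyl in place of the chloroacetyl group giving a 3.0-fold higher number from compound 2 to compound 4 (0.48 log units; beyond the scatter) in this series. No measurement at hand accounts for these differences.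

The compounds shown leave open how a simple methyl or benzyl group on the same ring nitrogen would read in this cytotoxicity series. They also leave open whether an acetyl group without the chlorine would keep the number of compound 2 or move it.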